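Swapping the Amide Substituent of Compound 3

The compounds below may be only part of what the source reports. "The series", "measured", "known", "first", "only" and "open" are said of these compounds alone.

Compound 1 `CCOC(=O)C(F)(F)C(O)CCc1ccccc1` in an assay on HEK-293T cells for inhibition of phospholipase A and acyltransferase 5 (Homo sapiens), with stated times of 30 min and 20 min (on this read-out lower numbers stand for stronger inhibition and higher numbers for weaker inhibition), gives > 10000 nM, which is a limit of the assay rather than a number.
Compound 2 `O=C(CCc1ccccc1)C(F)(F)C(=O)NCc1ccccc1` in this assay gives > 10000 nM, again a limit and not a number.
Compound 3 `CCNC(=O)C(=O)CCc1ccc(Cl)cc1` in this assay gives 1000 nM.

Among the measured compounds shown here, compound 3 therefore stands as the only compound of the three with a measured number; compounds 1 and 2 both sit at the limit of > 10000 nM in this assay, at which 2 of the 3 values shown sit. For the measured compounds named here, no step between two measured compounds exists here. There is nothing to show how large a change in this read-out a single structural edit tends to bring.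

Compound 4 `O=C(CCc1ccc(Cl)cc1)C(=O)N1CCOCC1` differs from compound 3 in one place: morpholin-4-yl in place of ethylamino on a carbonyl carbon. The remaining structure, the chain and the chlorine-bearing ring, is kept. Going by the values given here, with no measured step to lean on, the expectation for this change is modest: a step of about the size of the usual scatter, if anything toward weaker inhibition, so that the step from compound 3 to compound 4 is estimated at a 2.0-fold higher number from compound 3 to compound 4 (0.30 log units; within the scatter). For compound 4 in this assay the estimate is 2000 nM, with a range from 500 nM to 10000 nM.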

Compound 4, half-maximal inhibitory concentration: > 10000 nM
Compound 4 ended at the assay's limit; the forecaster's own chance of this, stated with the estimate: 25%; middle value at least 5.0-fold (0.69 log units) from the limit.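

Among the compounds shown here, the swap of ethylamino for morpholin-4-yl on a carbonyl carbon gives the first step in this set that can be sized, an at least 10-fold higher number from compound 3 to compound 4 (1.00 log units; beyond the scatter), and it shows that inhibition is sensitive to the group at this position. In this assay compound 4 gives > 10000 nM, which is a limit of the assay and not a number. For the compounds shown here, compound 3 therefore remains the only compound here with a measured number, and the morpholin-4-yl change moves the series back to the ceiling that the earlier compounds had already reached: the limit of > 10000 nM in this assay, at which 3 of the 4 values shown sit.

This single edit changes several things at once, since ethylamino brings one hydrogen-bond donor and no ring, while morpholin-4-yl brings no donor, one hydrogen-bond acceptor and a six-membered ring, and the compounds shown cannot say which of these differences matters. Piperidin-1-yl, a ring with no oxygen, would test the ring apart from its oxygen, while methylamino or a longer chain such as butylamino on the same carbonyl carbon would show whether the number of compound 3 can be improved.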